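A few compounds are considered here, and "the series" means these few. Any claim that something is new, unique, unknown or untested is made for them only; others in the source may bear on it.

Of the compounds shown here, two have so far been tested in a functional assay on the whole organism with Rattus norvegicus as the target, at a dose of 100 mg/kg; a higher number here means more inhibition at the dose given (going by the name of the read-out), a lower number less inhibition. Compound 1, `O=c1ccc(-c2ccccc2)nn1CCCCNC(=S)Nc1ccc(Cl)cc1`, gives 43.2%. Compound 2, `C/N=C(/NC#N)NCCCCn1nc(N2CCCC2)ccc1=O`, gives -1%, the lower of the two numbers, with compound 1 standing higher by a gap that lies beyond the usual scatter of this kind of measurement. Compound 3, `C/N=C(/NC#N)NCCCCn1nc(N2CCN(C)CC2)ccc1=O`, has not yet been measured. It differs from compound 2 in one place: 4-methylpiperazin-1-yl in place of pyrrolidin-1-yl on an aromatic carbon. The shared core and the chain are kept; only the ring on the aromatic carbon is exchanged. Among the compounds with values here, no measured pair shows what such an exchange does in this assay, so the expectation rests on compound 2 alone. Because compound 2 gives -1%, the expected step of a number 6 percentage points higher from compound 2 to compound 3 (within the scatter) is small, within the scatter and in no clear direction. Compound 3 is therefore estimated at 5%, in a range from -10% to 25%.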

Compound 3, a percentage reported as inhibition, in the whole organism at one dose (the size of the read-out at that dose, not a potency): 7.9%
Compound 3: the middle estimate sits 2.9 percentage points below what was measured, within the range that was stated.
By their numbers in this assay, from the lowest: compounds 2 and 3 (each within the scatter of the next); then compound 1.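

In this assay, within the data shown here, the exchange of pyrrolidin-1-yl for 4-methylpiperazin-1-yl on the aromatic carbon gives a number 8.9 percentage points higher from compound 2 to compound 3 (within the scatter) and thus the first reading of any change at this position. Replacing a five-membered ring with 1 hetero atom by a six-membered ring with 2 hetero atoms, and going from 1 to 2 hydrogen-bond acceptors, therefore leaves compound 2 and compound 3 indistinguishable in this whole-animal test. Nothing available explains this outcome.

Going by these compounds, it remains open whether a morpholin-4-yl ring or an open-chain dimethylamino group at this position would shift the read-out beyond the scatter. Compound 1 differs from compound 2 and compound 3 in more than one place, so it cannot show what this position alone contributes.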